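The compounds below may be only part of what the source reports. "The series", "measured", "known", "first", "only" and "open" are said of these compounds alone.

Three compounds sharing a sugar-bearing portion but differing in their cores were tested in an ADME assay on HEL cells (Homo sapiens) for cytotoxicity, read by cell counting, with a stated time of 3 days; on this read-out higher numbers stand for lower toxicity in this test and lower numbers for higher toxicity in this test. Compound 1 `CC(C)c1ccc(-n2cc(-c3cn([C@H]4C[C@H](O)[C@@H](CO)O4)c(=O)[nH]c3=O)nn2)cc1` gives only a limit in this assay, > 240000 nM. Compound 2 `O=c1[nH]c(=O)n([C@H]2C[C@H](O)[C@@H](CO)O2)cc1-c1cn(-c2ccc(Br)cc2)nn1` differs from compound 1 by bromo in place of isopropyl on an aromatic carbon. Compound 2 also gives only a limit, >= 44000 nM. The step that the two limits leave unreadable from compound 1 to compound 2 therefore cannot be read. Compound 3 `CC(C)c1ccc(-n2nncc2-c2cn([C@H]3C[C@H](O)[C@@H](CO)O3)c(=O)[nH]c2=O)cc1` has the same atoms as compound 1 joined differently; the difference between the two cores is not broken down here. Compound 3 gives only a limit in this assay, > 100000 nM. Compound 4 `O=c1[nH]c(=O)n([C@H]2C[C@H](O)[C@@H](CO)O2)cc1-c1cnnn1-c1ccc(Br)cc1` is not yet measured and differs from compound 3 by bromo in place of isopropyl on an aromatic carbon, the same kind of change as from compound 1 to compound 2, with the two places reading the same. For compound 4 the expected step is small, a number no higher from compound 3 to compound 4 (the limit leaves the size open), because every measured value sits at a limit, as the limit of >= 44000 nM in this assay, at which 1 of the 3 values shown sits, the limit of > 100000 nM in this assay, at which 1 of the 3 values shown sits, and the limit of > 240000 nM in this assay, at which 1 of the 3 values shown sits, show. Compound 4 is expected to give 100000 nM, most likely again as a limit.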

Compound 4, minimum cytotoxic concentration: > 100000 nM
Compound 4 ended at the assay's limit; the forecaster's own chance of this, stated with the estimate: 80%; the middle value lies on the limit itself.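

Among these compounds, the values of compound 3 and compound 4 are both limits, and no step between them can be read. The compounds shown leave open whether bromo and isopropyl differ at all in this assay.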